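This account rests on a few compounds, and the source may have more. Where it says the series, first, only, none or still open, it means among the compounds named here.

Compound 2 `CCC1([C@@H](O)C/C=C/[C@H]2[C@H](O)CC(=O)[C@@H]2C/C=C\CCCC(=O)O)CCC1` is one of two compounds tested in an assay on CHO cells for binding affinity to prostaglandin E2 receptor EP1 subtype (Mus musculus); a higher number here means a weaker inhibitor, a lower number a stronger inhibitor. For compound 2 the result is a limit of the assay rather than a number, at > 10000 nM. Compound 1 `CCCC1([C@@H](O)C/C=C/C2[C@H](O)CC(=O)[C@@H]2CCc2ccc(C(=O)O)cc2)CCC1`, which differs in both side chains, likewise returns only a limit in this assay, at > 10000 nM. Both values shown fall at the limit of > 10000 nM in this assay, at which 2 of the 2 values shown sit, so compound 2 stands at the weak edge of what this assay reports, with no stronger comparator in view.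

Compound 3 `CCCCCC1([C@@H](O)C/C=C/[C@H]2[C@H](O)CC(=O)[C@@H]2C/C=C\CCCC(=O)O)CCC1` differs from compound 2 by propyl in place of hydrogen on a saturated chain carbon, two bonds along the chain from a saturated ring carbon. Within the data shown here, no measured pair shows this change, so the size of the step is unknown; any shift is expected to stay within the scatter, with the limit most likely repeated. The step from compound 2 to compound 3 is therefore estimated as a number no higher from compound 2 to compound 3 (the limit leaves the size open). Compound 3 is expected to give about 10000 nM, in the range 3000 nM to 30000 nM.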

Compound 3, inhibition constant: 1600 nM
Compound 3: middle estimate off by 6.3-fold (0.80 log units), on the high side; measured number outside the range, below it.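

In this assay, propyl in place of hydrogen on a saturated chain carbon, two bonds along the chain from a saturated ring carbon, turns 1-ethylcyclobutyl into 1-pentylcyclobutyl and gives an at least 6.2-fold lower number from compound 2 to compound 3 (0.79 log units; beyond the scatter). Among these compounds, this is the first sign that this position can move the result off the limit, and compound 3 is the only one of the three compounds that returns a number. From the compounds shown here alone, the true size of the step stays unknown because compound 2 gives a limit and not a number: the limit of > 10000 nM in this assay, at which 2 of the 3 values shown sit.

The compounds shown leave open whether a chain longer than pentyl, or an amine at the end of the pentyl chain, would lower the number further. They also leave open whether 1-pentylcyclobutyl would have the same effect with the other side chain of compound 1.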